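Alkyne substituent change from compound 3 to compound 4

A few compounds are considered here, and "the series" means these few. Any claim that something is new, unique, unknown or untested is made for them only; others in the source may bear on it.

Compound 3 `CC1(C#Cc2c(Cl)c3c(Cl)cc(C(N)=O)nc3n2[C@H]2CCCNC2)COC1` gives the smaller of the two single numbers in a functional assay on KG-1 cells (Homo sapiens) for antiproliferative activity (a higher number here means that more compound is needed for the effect, a lower number that less compound is needed), at 119 nM, a difference that lies within the scatter. Compound 1 `CN1CC(C#Cc2c(Cl)c3c(Cl)cc(C(N)=O)nc3n2[C@H]2CCCNC2)CC1=O` gives 155 nM in this assay, and a 1.3-fold lower number from compound 1 to compound 3 (0.11 log units; within the scatter). Compound 2 `NC(=O)c1cc(Cl)c2c(Cl)c(C#CC3CNCCO3)n([C@H]3CCCNC3)c2n1` has two entries in this assay, 365 nM; 197 nM (2 entries), and the spread between them (the several entries of compound 2 in this assay, 365 nM; 197 nM (2 entries)) shows how far repeats of this measurement can drift. Compound 4 `COCC(C)(C)C#Cc1c(Cl)c2c(Cl)cc(C(N)=O)nc2n1[C@H]1CCCNC1` carries the change (1-(methoxymethyl)-1-methylethyl in place of 3-methyloxetan-3-yl on a triple-bonded carbon). Going by the values given here, the only measured step at this position, a 1.3-fold lower number from compound 1 to compound 3 (0.11 log units; within the scatter), stayed within the scatter. The change to compound 4 is therefore expected to give no step beyond the scatter in this assay, a 1.1-fold higher number from compound 3 to compound 4 (0.04 log units; within the scatter). Compound 4 is estimated at 130 nM, with a range from 55 nM to 310 nM.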

Compound 4, half-maximal effective concentration: 219 nM
Compound 4: the middle estimate sits 1.7-fold (0.23 log units) below what was measured; low and high end bracket the measured number.
By their numbers in this assay, from the lowest: compounds 3, 1 and 4 (each within the scatter of the next).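

In this assay, the ring of 3-methyloxetan-3-yl is not needed at this position on the triple-bonded carbon: the open-chain 1-(methoxymethyl)-1-methylethyl group gives a 1.8-fold higher number from compound 3 to compound 4 (0.26 log units; within the scatter). Against 1-methyl-5-oxopyrrolidin-3-yl, the same group gives a 1.4-fold higher number from compound 1 to compound 4 (0.15 log units; within the scatter), so these three substituents remain unseparated. Steps of this size are read alongside the drift between repeats: the several entries of compound 2 in this assay, 365 nM; 197 nM (2 entries)

As far as these compounds go, whether a carboxylic acid, a phenyl ring or a longer alkyl chain on the triple-bonded carbon would move the number beyond the scatter stays open.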